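The compounds below may be only part of what the source reports. "The series", "measured", "known", "first", "only" and "open" are said of these compounds alone.

In a functional assay on FaDu cells (Homo sapiens) for cytotoxicity, read by MTT assay, with a stated time of 72 h (a lower number here means that less compound is tolerated, a higher number that more compound is tolerated), compound 1 `COc1ccc(NC(=O)C(=O)c2cn(C(C)C)c3ccccc23)cc1` gives 181 nM and compound 3 `COC(=O)CCn1cc(C(=O)C(=O)Nc2ccc(OC)nc2)c2ccccc21` gives 168 nM, two numbers within the scatter of each other. Compound 2 `CCn1cc(C(=O)C(=O)Nc2ccncc2)c2ccccc21` returns only a limit of > 10000 nM and no number. Compound 3 thus stands level with compound 1. Compound 4 `CCCCn1cc(C(=O)C(=O)Nc2ccc(OC)nc2)c2ccccc21` has ethyl in place of methoxycarbonyl on a saturated chain carbon, two bonds along the chain from an aromatic nitrogen. Among the compounds with values here, no measured pair isolates this change. Compound 1 carries no methoxycarbonyl and gives 181 nM in this assay so no step beyond the scatter is expected. The expected step (a 1.1-fold lower number from compound 3 to compound 4 (0.05 log units; within the scatter)) stays within that scatter. The estimated value for compound 4 is 150 nM (expected range 50 nM to 500 nM).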

Compound 4, concentration lethal to 50% of the cells: 18 nM
Estimate against measurement, compound 4: 8.3-fold (0.92 log units) above, and the stated range ends above it.
By their numbers in this assay, from the lowest: compound 4; then compounds 3 and 1 (each within the scatter of the next). At a limit, above all of these: compound 2.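

In this assay ethyl in place of methoxycarbonyl on a saturated chain carbon, two bonds along the chain from an aromatic nitrogen, gives a 9.3-fold lower number from compound 3 to compound 4 (0.97 log units; beyond the scatter) and shows that the number responds to this position. Among the earlier compounds no pair differed in one place, so this step is the only direct reading of the chain end. Nothing measured here accounts for the step. Still open, from the compounds shown here alone, is how a longer chain such as hexyl, or a carboxylic acid or an amine at the chain end, would read. One step gives no trend.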